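Working notes on acyl variation at the aryl oxygen

This account rests on a few compounds, and the source may have more. Where it says the series, first, only, none or still open, it means among the compounds named here.

Measured compounds:
Compound 1 `COc1ccc(/C=C/C(=O)c2ccc(OC)c3c2OC(C)(C)C=C3)cc1OCCO`: 8750 nM
Compound 2 `COc1ccc(/C=C/C(=O)c2ccc(OC)c3c2OC(C)(C)C=C3)cc1OC(=O)CCl`: 400 nM
Compound 3 `COc1cccc(C(=O)Oc2cc(/C=C/C(=O)c3ccc(OC)c4c3OC(C)(C)C=C4)ccc2OC)c1`: 790 nM

In a functional assay on K562 cells (Homo sapiens) for cytotoxicity, read by MTT assay (on this read-out higher numbers stand for weaker inhibition and lower numbers for stronger inhibition), compound 3 gives 790 nM, the second highest of the three numbers. Its nearest neighbour is compound 2: a 2.0-fold higher number from compound 2 to compound 3 (0.30 log units; within the scatter). Its furthest is compound 1: an 11-fold lower number from compound 1 to compound 3 (1.04 log units; beyond the scatter).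

Compound 4 `COc1ccc(/C=C/C(=O)Oc2cc(/C=C/C(=O)c3ccc(OC)c4c3OC(C)(C)C=C4)ccc2OC)cc1` is not yet measured in this assay. It differs from compound 3 in one place: 2-(4-methoxyphenyl)ethenyl in place of 3-methoxyphenyl on a carbonyl carbon.

Among the compounds with values here, two measured steps bear on this. Replacing the 2-hydroxyethyl group by an acyl group gave large steps, a 22-fold lower number from compound 1 to compound 2 (1.34 log units; beyond the scatter) and an 11-fold lower number from compound 1 to compound 3 (1.04 log units; beyond the scatter); compound 4 keeps the ester, so that gain should be retained. Changing the group on the carbonyl carbon gave a 2.0-fold higher number from compound 2 to compound 3 (0.30 log units; within the scatter). The step to compound 4 is of the second kind, so no step beyond the scatter is expected in this assay; a 1.1-fold lower number from compound 3 to compound 4 (0.05 log units; within the scatter) is the expected size.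

Compound 4 is therefore estimated at 700 nM, with a range from 250 nM to 2000 nM.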

Compound 4, half-maximal inhibitory concentration: 380 nM
The estimate for compound 4 lay 1.8-fold (0.27 log units) above the measured number, and the stated range covers the measured number.
By their numbers in this assay, from the lowest: compounds 4, 2 and 3 (each within the scatter of the next, the first and the last beyond it); then compound 1.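

In this assay, the group on the carbonyl carbon can move the number beyond the scatter, which the earlier chloromethyl to 3-methoxyphenyl step did not show: 2-(4-methoxyphenyl)ethenyl in place of 3-methoxyphenyl gives a modest step (a 2.1-fold lower number from compound 3 to compound 4 (0.32 log units; beyond the scatter)). The same group in place of chloromethyl stays within the scatter (a 1.1-fold lower number from compound 2 to compound 4 (0.02 log units; within the scatter)), so these two very different groups are not separated here. The large gain over the 2-hydroxyethyl group now holds for a third acyl group (a 23-fold lower number from compound 1 to compound 4 (1.36 log units; beyond the scatter)).

From the compounds shown here alone, whether the modest step follows from the double bond or from the shift of the methoxy group stays open, as does how an amine or a carboxylic acid on the acyl group would read. No measurement at hand accounts for these steps.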